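A few compounds are considered here, and "the series" means these few. Any claim that something is new, unique, unknown or untested is made for them only; others in the source may bear on it.

In an ADME assay on Vero cells (Chlorocebus sabaeus) for cytotoxicity, read by neutral red uptake, tested at 787 ug/mL (on this read-out lower numbers stand for a stronger effect and higher numbers for a weaker effect at the one concentration tested), compound 1 `O=C1CSC(c2cccc(O)c2)N1CCN1CCCCC1` gives 60%, the highest of the three numbers measured. Compound 2 `O=C1CSC(c2ccc(O)cc2)N1CCN1CCCCC1` gives 57% in this assay, and the step of a number 3 percentage points lower from compound 1 to compound 2 (within the scatter) shows the two hydroxyphenyl compounds side by side. Compound 3 `O=C1CSC(c2ccc(F)cc2)N1CCN1CCCCC1` gives 17%, and the step of a number 43 percentage points lower from compound 1 to compound 3 (beyond the scatter) is the furthest from compound 1, with a number 40 percentage points lower from compound 2 to compound 3 (beyond the scatter) showing the same kind of fall when only the hydroxy is exchanged for fluoro.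

Compound 4 `COc1cccc(C2SCC(=O)N2CCN2CCCCC2)c1` differs from compound 1 in one place: methyl in place of hydrogen on an oxygen on an aromatic ring. Among the measured compounds shown here, no measured step carries exactly this change. The step from compound 1 to compound 2, which moves the hydroxy, stayed within the scatter, whereas the step from compound 2 to compound 3, which removes the hydroxy, was large. Since compound 4 also no longer carries a hydroxy, a drop from compound 1 is expected, though its size is uncertain, so the estimated step is a number 22 percentage points lower from compound 1 to compound 4 (beyond the scatter). Compound 4 is therefore expected to give about 38% in this assay, in a range from 12% to 64%.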

Compound 4, a percentage reported as activity, at one concentration (the size of the read-out at that concentration, not a potency): 19%
Compound 4: middle estimate off by 19 percentage points, on the high side, within the range that was stated.
By their numbers in this assay, from the lowest: compounds 3 and 4 (each within the scatter of the next); then compounds 2 and 1 (each within the scatter of the next).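

Adding a single methyl to the oxygen of the hydroxy in compound 1, with the group staying in the same place on the ring, is enough to produce a large change in this assay (a number 41 percentage points lower from compound 1 to compound 4 (beyond the scatter)). The earlier fall (a number 40 percentage points lower from compound 2 to compound 3 (beyond the scatter)) came with the loss of the oxygen itself, whereas here the oxygen stays and only its hydrogen is replaced, so keeping that oxygen does not preserve the higher number. The compounds shown offer no measured explanation for this effect. Going by these compounds, it remains open whether a longer chain on the oxygen, such as ethoxy, or an amine in place of the hydroxy would read like compound 1 or compound 4. On these data alone, the effect of the same methyl on the oxygen of compound 2 also remains open.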